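This account rests on a few compounds, and the source may have more. Where it says the series, first, only, none or still open, it means among the compounds named here.

Measured in an ADME assay on microsomes from liver (Homo sapiens) for metabolic stability, tested at 2.5 uM; a higher number here means faster removal of the compound, a lower number slower removal:

- compound 1 `O=S(=O)(c1ccc(F)cc1)c1cnc2c(F)cccc2c1-c1cccc(Cl)c1`: 1.21 mL/min
- compound 2 `O=S(=O)(c1ccc(F)c(F)c1)c1cnc2c(F)cccc2c1-c1cccc(Cl)c1`: 1.13 mL/min
- compound 3 `O=S(=O)(c1cc(F)cc(F)c1)c1cnc2c(F)cccc2c1-c1cccc(Cl)c1`: 0.64 mL/min

Compound 1 gives the highest of the three numbers in this assay, but its gaps to the others are small: a 1.1-fold lower number from compound 1 to compound 2 (0.03 log units; within the scatter) and a 1.9-fold lower number from compound 1 to compound 3 (0.28 log units; within the scatter), both within the scatter, as is a 1.8-fold lower number from compound 2 to compound 3 (0.25 log units; within the scatter). On these numbers the three compounds cannot be told apart.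

Compound 4 `O=S(=O)(c1ccc(F)cc1)c1cnc2c(F)cccc2c1-c1cccc(F)c1` is not yet measured. It differs from compound 1 only in one place: fluoro in place of chloro on an aromatic carbon. For the measured compounds named here, none of the measured steps touches this position; all three concern the ring on the sulfonyl sulfur, and none of them moved the number beyond the scatter. Going by the values given here, there is therefore no direct precedent for the exchange in compound 4, and the only indication the series gives is that single-atom changes on the aromatic periphery have so far left this assay essentially unchanged.

The expectation for compound 4 is accordingly a step of a 1.1-fold lower number from compound 1 to compound 4 (0.04 log units; within the scatter), that is, no change beyond the scatter. The estimated value for compound 4 in this assay is 1.1 mL/min, with a range from 0.6 mL/min to 2 mL/min.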

Compound 4, intrinsic clearance in a liver preparation (reported as CLH), per the amount of preparation that the assay uses: 1.56 mL/min
Compound 4: the middle estimate sits 1.4-fold (0.15 log units) below what was measured; measured number inside the range.
By their numbers in this assay, from the lowest: compounds 3, 2, 1 and 4 (each within the scatter of the next, the first and the last beyond it).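

In this assay the exchange of chloro for fluoro, which turns the 3-chlorophenyl into a 3-fluorophenyl, gives a 1.3-fold higher number from compound 1 to compound 4 (0.11 log units; within the scatter) and so adds a reading at a position outside the ring on the sulfonyl sulfur. At this position, on an aromatic carbon and meta to a large group, one halogen can replace the other without a shift that can be separated from the scatter, so the two halogens cannot be told apart here. Every one-place step shown, whether on the ring on the sulfonyl sulfur or on this ring, now lies within the scatter, although no data accompany this step that would help to interpret it.

Going by these compounds, what a group other than a halogen does at this position stays open: a methoxy, an amine or a carboxylic acid in place of the chloro could still move the number beyond the scatter, and the plain phenyl offers a further comparison. On these data alone, the fluoro on the shared core is common to all four compounds, so the effect of exchanging it for hydrogen or a nitrile also remains open.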